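Moving the Sulfur Within the Thiophene Ring

The source may report more compounds than this note shows. Statements on the series, on what has been measured and on what is new or still open speak of the compounds shown alone.

Among the compounds with values here, in a functional assay on SK-BR-3 cells (Homo sapiens) for antiproliferative activity, read by XTT assay, with a stated time of 72 h (a higher number here means a weaker inhibitor, a lower number a stronger inhibitor), compound 3 `COc1ccc(-c2cc3ccccc3nc2/C=C/C(=O)c2cccs2)cc1` gives 800 nM, the strongest of the three compounds measured so far. Compound 1 `COc1ccc(-c2cc3ccccc3nc2/C=C/C(=O)c2ccc(O)cc2)cc1` gives 3880 nM and compound 2 `COc1ccc(-c2cc3ccccc3nc2/C=C/C(=O)c2ccc(OC)c(OC)c2)cc1` gives 3260 nM. The measured steps all swap one whole ring for another: a 4.9-fold lower number from compound 1 to compound 3 (0.69 log units; beyond the scatter) and a 4.1-fold lower number from compound 2 to compound 3 (0.61 log units; beyond the scatter), while a 1.2-fold lower number from compound 1 to compound 2 (0.08 log units; within the scatter). Compound 4 `COc1ccc(-c2cc3ccccc3nc2/C=C/C(=O)c2ccsc2)cc1` keeps the same atoms as compound 3, joined differently: thiophen-3-yl in place of thiophen-2-yl on a carbonyl carbon. Within the data shown here, none of the measured steps touches a shift of this kind inside a single ring, so the measured numbers give no direction, and no change beyond the scatter is expected. Compound 4 is therefore expected to give 1000 nM, in a range from 400 nM to 2500 nM. The expected step is a 1.3-fold higher number from compound 3 to compound 4 (0.10 log units; within the scatter).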

Compound 4, half-maximal inhibitory concentration: 660 nM
Estimate against measurement, compound 4: 1.5-fold (0.18 log units) above, and the stated range covers the measured number.
By their numbers in this assay, from the lowest: compounds 4 and 3 (each within the scatter of the next); then compounds 2 and 1 (each within the scatter of the next).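

In this assay, moving the attachment point within the thiophene ring makes no change beyond the scatter (a 1.2-fold lower number from compound 3 to compound 4 (0.08 log units; within the scatter)). Thiophen-3-yl keeps the advantage over the substituted phenyl groups (a 4.9-fold lower number from compound 2 to compound 4 (0.69 log units; beyond the scatter); a 5.9-fold lower number from compound 1 to compound 4 (0.77 log units; beyond the scatter)), so that advantage is not confined to thiophen-2-yl. No measurement available here explains this result. Going by these compounds, it remains open whether furan-2-yl, with oxygen in place of sulfur, would perform like the thiophenes. A methyl or chloro group on the thiophene ring is equally untested by the compounds shown.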